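The source may report more compounds than this note shows. Statements on the series, on what has been measured and on what is new or still open speak of the compounds shown alone.

Measured in an ADME assay on CCRF-CEM cells (Homo sapiens) for cytotoxicity, with a stated time of 4 days; on this read-out higher numbers stand for lower toxicity in this test and lower numbers for higher toxicity in this test:
- compound 1 `CNC(=O)CCCCn1c(=O)c(C)cn([C@@H]2O[C@H](CO[Si](C)(C)C(C)(C)C)[C@@]3(OS(=O)(=O)C=C3N)[C@H]2O[Si](C)(C)C(C)(C)C)c1=O`: 10000 nM
- compound 2 `Cc1cn([C@@H]2O[C@H](CO[Si](C)(C)C(C)(C)C)[C@@]3(OS(=O)(=O)C=C3N)[C@H]2O[Si](C)(C)C(C)(C)C)c(=O)n(C(=O)OC(C)(C)C)c1=O`: 26000 nM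
- compound 3 `COC(=O)n1c(=O)c(C)cn([C@@H]2O[C@H](CO[Si](C)(C)C(C)(C)C)[C@@]3(OS(=O)(=O)C=C3N)[C@H]2O[Si](C)(C)C(C)(C)C)c1=O`: > 100000 nM, a limit and not a number

Compound 3 stands at the limit of > 100000 nM in this assay, at which 1 of the 3 values shown sits.

Next is compound 4 `Cc1cn([C@@H]2O[C@H](CO[Si](C)(C)C(C)(C)C)[C@@]3(OS(=O)(=O)C=C3N)[C@H]2O[Si](C)(C)C(C)(C)C)c(=O)n(C(=O)CCCBr)c1=O`, with the change 3-bromopropyl in place of methoxy on a carbonyl carbon: methoxycarbonyl to (3-bromopropyl)carbonyl. Three measured steps swap this same substituent: an at least 3.8-fold higher number from compound 2 to compound 3 (0.58 log units; beyond the scatter), an at least 10-fold higher number from compound 1 to compound 3 (1.00 log units; beyond the scatter) and a 2.6-fold higher number from compound 1 to compound 2 (0.41 log units; beyond the scatter). Neither compound 1 nor compound 2 reaches the limit of compound 3, so a step to a lower number is expected in this assay, of modest size at least. The expected step is an at least 4.0-fold lower number from compound 3 to compound 4 (0.60 log units; beyond the scatter). For compound 4 the estimate is 25000 nM, with a range of 7000 nM to 90000 nM.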

Compound 4, half-maximal cytotoxic concentration: 11000 nM
Compound 4: middle estimate off by 2.3-fold (0.36 log units), on the high side; the range from low to high includes it.
By their numbers in this assay, from the lowest: compounds 1 and 4 (each within the scatter of the next); then compound 2. At a limit, above all of these: compound 3.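

On the aromatic nitrogen, (3-bromopropyl)carbonyl gives a value in this assay that sits with the 4-(methylcarbamoyl)butyl group of compound 1, with a 1.1-fold higher number from compound 1 to compound 4 (0.04 log units; within the scatter). On the carbonyl carbon, 3-bromopropyl in place of tert-butoxy gives a 2.4-fold lower number from compound 2 to compound 4 (0.37 log units; beyond the scatter), so the carbonyl alone does not set the number. 3-Bromopropyl in place of methoxy gives an at least 9.0-fold lower number from compound 3 to compound 4 (0.95 log units; beyond the scatter), a step that rests on a limit: the limit of > 100000 nM in this assay, at which 1 of the 4 values shown sits.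

On these data alone, whether the bromine or the propyl chain goes with the lower number stays open. A propyl group without bromine, or an amine in place of the bromine, would separate the two.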